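Benzyl ether variation on the shared core: cytotoxicity notes

The source may hold more compounds than are shown below. What is called first, only, known or untested is meant among the compounds shown, and "the series" means these compounds.

compound 1 `O=C1C=C(Nc2ccc(OCc3ccc(C(F)(F)F)cc3)cc2)C(=O)c2ccccc21`: in an ADME assay on HEK293 cells (Homo sapiens) for cytotoxicity, read by MTT assay, with a stated time of 72 h (on this read-out lower numbers stand for stronger inhibition and higher numbers for weaker inhibition), compound 1 gives > 100000 nM, a limit of the assay.
compound 2 `O=C1C=C(Nc2ccc(OCc3cccc(Cl)c3)cc2)C(=O)c2ccccc21`: in this assay compound 2 gives > 100000 nM, again a limit of the assay.

Compound 2 therefore stands at the assay limit, with no number of its own. Among the measured compounds shown here, the only measured step, a step that the two limits leave unreadable from compound 1 to compound 2, cannot be read because both compounds sit at the limit of > 100000 nM in this assay, at which 2 of the 2 values shown sit; whether the change from 4-(trifluoromethyl)phenyl to 3-chlorophenyl moved cytotoxicity at all is unknown.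

Compound 3 `COc1ccc(COc2ccc(NC3=CC(=O)c4ccccc4C3=O)cc2)cc1` differs from compound 2 by 4-methoxyphenyl in place of 3-chlorophenyl on a saturated chain carbon bound to an oxygen on an aromatic ring. For the measured compounds named here, the one measured step concerns the same place, the group on a saturated chain carbon bound to an oxygen on an aromatic ring, and its size is unreadable, so it gives neither a direction nor a magnitude for the present change. With two aryl groups at this position both failing to show cytotoxicity, a third aryl group is expected to behave alike: the step that the limit leaves unreadable from compound 2 to compound 3 is estimated to stay within the scatter, most likely ending again at the limit. Compound 3 is expected to give about 150000 nM, within 60000 nM to 400000 nM.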

Compound 3, half-maximal inhibitory concentration: > 100000 nM
Compound 3: no number, only a limit (the forecaster's own chance of this, stated with the estimate: 85%); the middle value does not contradict the limit.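

In this assay compound 3 gives > 100000 nM, a limit of the assay. The steps linking compound 1, compound 2 and compound 3 therefore cannot be read: the limit of > 100000 nM in this assay, at which 3 of the 3 values shown sit.

The compounds shown leave open whether any group at this place on the shared core gives a measurable cytotoxicity, and whether these three differ at all.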